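The source may hold more compounds than are shown below. What is called first, only, known or untested is meant among the compounds shown, and "the series" means these compounds.

Working notes on the series. Compound 1 `CCCCCC(=O)O[C@]12C=CC(=O)C[C@H]1OCC2` and compound 2 `CCCCCCCC(=O)O[C@]12C=CC(=O)C[C@H]1OCC2` share one core; compound 3 `CCCCCC(=O)O[C@]12C=CC(O)C[C@H]1OCC2` and compound 4 `CCCCCCCC(=O)O[C@]12C=CC(O)C[C@H]1OCC2` share another, and the difference between the two cores is not broken down here. In a functional assay on P388 cells (Mus musculus) for cytotoxicity (on this read-out higher numbers stand for weaker inhibition and lower numbers for stronger inhibition), compound 1 gives 0.3 ug/mL, compound 2 gives 0.3 ug/mL and compound 3 gives 38.5 ug/mL, the highest of the three numbers and beyond the scatter from both others. The change ethyl in place of hydrogen on a saturated chain carbon, five bonds along the chain from a carbonyl carbon gave no change at the digits printed from compound 1 to compound 2 (within the scatter). The same change ethyl in place of hydrogen on a saturated chain carbon, five bonds along the chain from a carbonyl carbon separates compound 3 from compound 4, so it occurs twice among these compounds. In this assay, within the data shown here, the step expected to compound 4 is a 1.0-fold lower number from compound 3 to compound 4 (0.01 log units; within the scatter), resting on no change at the digits printed from compound 1 to compound 2 (within the scatter) as the only precedent, which leaves room for doubt. Compound 4 is estimated at 38 ug/mL, within 14 ug/mL to 100 ug/mL.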

Compound 4, half-maximal inhibitory concentration: 8.4 ug/mL
The estimate for compound 4 lay 4.5-fold (0.66 log units) above the measured number, outside the stated range (below it).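

In this assay, ethyl in place of hydrogen on a saturated chain carbon, five bonds along the chain from a carbonyl carbon, gives a 4.6-fold lower number from compound 3 to compound 4 (0.66 log units; beyond the scatter), while on the other core it gives no change at the digits printed from compound 1 to compound 2 (within the scatter). The size of this step therefore did not carry from one core to the other: the same change on two cores in this assay, no change at the digits printed (within the scatter) from compound 1 to compound 2 and a 4.6-fold lower number (0.66 log units; beyond the scatter) from compound 3 to compound 4, 4.6-fold (0.66 log units) apart, beyond the scatter of two such steps These two pairs show that the step can depend on the core, but they do not explain the gap or give a rule for any further core.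

The compounds shown leave open how a longer chain would behave on either core. They also leave open whether an amine or a carboxylic acid at the end of the chain would keep or lose the step.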